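Replacing the 3-bromo-4-hydroxy-5-methoxyphenyl group of compound 2

The source may report more compounds than this note shows. Statements on the series, on what has been measured and on what is new or still open speak of the compounds shown alone.

In a functional assay on HepG2 cells (Homo sapiens) for antiproliferative activity, read by sulforhodamine B assay, with a stated time of 48 h (a higher number here means a weaker inhibitor, a lower number a stronger inhibitor), compound 1 (`COc1cc(C=C(C(=O)/C=C/c2cccc(OC)c2OC)C(=O)/C=C/c2cccc(OC)c2OC)ccc1O`) gives 200 nM and compound 2 (`COc1cc(C=C(C(=O)/C=C/c2cccc(OC)c2OC)C(=O)/C=C/c2cccc(OC)c2OC)cc(Br)c1O`) gives 240 nM. Going by the values given here, these are the only two numbers so far, and they lie within the scatter of each other, so compound 2 stands level with compound 1. Among the compounds with values here, the one measured step, a 1.2-fold higher number from compound 1 to compound 2 (0.08 log units; within the scatter), is bromo in place of hydrogen on an aromatic carbon, and it stays within the scatter.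

Compound 3 (`COc1cccc(/C=C/C(=O)C(=Cc2ccc(OC)c(OC)c2OC)C(=O)/C=C/c2cccc(OC)c2OC)c1OC`) has not yet been measured. Its difference from compound 2 is this: 2,3,4-trimethoxyphenyl in place of 3-bromo-4-hydroxy-5-methoxyphenyl on a double-bonded chain carbon bound to a double-bonded chain carbon. Within the data shown here, the bromo step touched the group that now leaves, but it did not replace that group whole, and no measured compound carries 2,3,4-trimethoxyphenyl at this place. That single step is therefore a weak guide, and it gives no ground to expect a large change in this assay. The expected step is a 1.3-fold higher number from compound 2 to compound 3 (0.10 log units; within the scatter), with no shift beyond the scatter foreseen, although the uncertainty is wide. Compound 3 is estimated at 300 nM, with an expected range of 90 nM to 1200 nM.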

Compound 3, half-maximal inhibitory concentration: 240 nM
Beside the measured number, compound 3's estimate is 1.3-fold (0.10 log units) above it, within the range that was stated.
By their numbers in this assay, from the lowest: compounds 1, 2 and 3 (each within the scatter of the next).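

Compound 3 shows that, in this assay, the whole phenyl group on a double-bonded chain carbon bound to a double-bonded chain carbon can be exchanged, and not only one substituent on it, with the number staying level: 2,3,4-trimethoxyphenyl in place of 3-bromo-4-hydroxy-5-methoxyphenyl gives (no change at the digits printed from compound 2 to compound 3 (within the scatter)). The same entering group in place of 4-hydroxy-3-methoxyphenyl gives (a 1.2-fold higher number from compound 1 to compound 3 (0.08 log units; within the scatter)), so compound 1, compound 2 and compound 3 all stand within the scatter of each other. At this place, then, the bromine and the one hydrogen-bond donor of the group leaving compound 2 can both be absent from compound 3 without a step beyond the scatter.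

No measurement of any property is available that would account for these three numbers standing level. The compounds shown leave open whether a phenyl group carrying an amine or a carboxylic acid at this place would also stay level, and whether the two 2,3-dimethoxyphenyl groups of the shared core can be exchanged in the same way.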